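Extending the chain of compound 3: cytotoxicity notes

A few compounds are considered here, and "the series" means these few. Any claim that something is new, unique, unknown or untested is made for them only; others in the source may bear on it.

Measured in an ADME assay on A549 cells (Homo sapiens) for cytotoxicity, read by MTT assay; on this read-out lower numbers stand for higher toxicity in this test and higher numbers for lower toxicity in this test:
- compound 1 `CCCCCCCCCCNc1ccn([C@H]2C[C@H](O)[C@@H](CO)O2)c(=O)n1`: 200000 nM
- compound 2 `CCCCCCCCCCCCCCNc1ccn([C@H]2C[C@H](O)[C@@H](CO)O2)c(=O)n1`: 90000 nM
- compound 3 `CCCCCCNc1nc(=O)n([C@H]2C[C@H](O)[C@@H](CO)O2)cc1C`: 90000 nM

In this assay compound 3 gives 90000 nM, the same number as compound 2, and the two share the lowest number of the three. Compound 1 stands higher at 200000 nM.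

Compound 4 `CCCCCCCCCCCCNc1nc(=O)n([C@H]2C[C@H](O)[C@@H](CO)O2)cc1C` carries hexyl in place of hydrogen on a saturated chain carbon, six bonds along the chain from a nitrogen on an aromatic ring.

Going by the values given here, only one measured step bears on this change: a 2.2-fold lower number from compound 1 to compound 2 (0.35 log units; beyond the scatter), a modest move to a lower number on adding butyl to a chain. That step was measured on the core of compound 1, which is not the core of compound 3, so the transfer is uncertain. The addition here is larger, so a modest step in the same direction is expected: a 2.3-fold lower number from compound 3 to compound 4 (0.35 log units; beyond the scatter) is the estimated change in this assay.

For compound 4 the estimated value is 40000 nM, with an expected range of 15000 nM to 100000 nM.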

Compound 4, half-maximal cytotoxic concentration: 158000 nM
The estimate for compound 4 lay 4.0-fold (0.60 log units) below the measured number, outside the stated range (above it).
By their numbers in this assay, from the lowest: compounds 2, 3, 4 and 1 (each within the scatter of the next, the first and the last beyond it).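

In this assay, hexyl in place of hydrogen on a saturated chain carbon, six bonds along the chain from a nitrogen on an aromatic ring, gives a 1.8-fold higher number from compound 3 to compound 4 (0.24 log units; within the scatter), so this extension on the core of compound 3 produces no move beyond the scatter. The chain addition on the core of compound 1 gave a 2.2-fold lower number from compound 1 to compound 2 (0.35 log units; beyond the scatter), and that lower number does not carry over to this pair, although one pair on each core is too little to set a rule for either. No available evidence accounts for this result.

Still open, from the compounds shown here alone, is whether a longer chain on the core of compound 3 would move the number beyond the scatter. Also open, going by these compounds, is how this read-out would respond to an amine or a carboxylic acid carried on the chain.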